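Moving the Methyl Around the Aryl Ring of Compound 1

This account rests on a few compounds, and the source may have more. Where it says the series, first, only, none or still open, it means among the compounds named here.

Of the compounds shown here, two of this set have been tested in an ADME assay on HEL cells (Homo sapiens) for cytotoxicity, read by microscopy; on this read-out lower numbers stand for higher toxicity in this test and higher numbers for lower toxicity in this test. In this assay compound 1 `Cc1ccccc1OCCCCCn1ccc(=O)[nH]c1=O` shows only a limit, > 100000 nM. Compound 2 `O=c1ccn(CCCOc2ccc(Br)cc2)c(=O)[nH]1` likewise gives only a limit in this assay, namely > 100000 nM. Going by the values given here, both results sit at the limit of > 100000 nM in this assay, at which 2 of the 2 values shown sit, so no step between measured compounds can be drawn, and compound 1 stands simply at that shared limit, neither higher nor lower than the other compound in any way the numbers can show.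

Compound 3 `Cc1cccc(OCCCCCn2ccc(=O)[nH]c2=O)c1` has not yet been measured in this assay. It differs from compound 1 by 3-methylphenyl in place of 2-methylphenyl on an oxygen on a saturated carbon. Among the compounds with values here, with no measured step to indicate what such a change does, the step from compound 1 to compound 3 in this assay is expected to be none beyond the scatter, a number no higher from compound 1 to compound 3 (the limit leaves the size open). Compound 3 is accordingly estimated to give about 100000 nM in this assay, within 50000 nM to 300000 nM, most probably once more as a limit rather than a number.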

Compound 3, minimum cytotoxic concentration: > 100000 nM
Compound 3: a limit, no number (the forecaster's own chance of this, stated with the estimate: 90%); the middle value lies on the limit itself.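

Compound 3, like compound 1, gives only a limit and no number in this assay, so no step can be read between the two compounds: the limit of > 100000 nM in this assay, at which 3 of the 3 values shown sit.

The compounds shown leave open whether 3-methylphenyl in place of 2-methylphenyl makes any difference to this read-out.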